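The compounds below may be only part of what the source reports. "The series", "measured", "known", "first", "only" and "open" are said of these compounds alone.

Measured so far in an in vitro ADME assay on microsomes from liver (Canis lupus familiaris) for metabolic stability, tested at 5 uM; a higher number here means that the compound lasts longer, a lower number that the compound disappears faster:
- Compound 1 `C=CC(=O)NCc1coc(-c2c(N)ncnc2Nc2ccc(Oc3cc(Cl)ccc3Cl)c(Cl)c2)n1`; in this assay compound 1 sits at the limit > 1.66 h.
- Compound 2 `C=CC(=O)NCc1coc(-c2c(N)ncnc2Nc2ccc(Oc3ccc(F)cc3)c(Cl)c2)n1`; in this assay compound 2 likewise sits at the limit > 1.66 h.
- Compound 3 `C=CC(=O)NCc1coc(-c2c(N)ncnc2Nc2ccc(F)c(Cl)c2)n1`; in this assay compound 3 gives 0.15 h.

For the measured compounds named here, compound 3 holds the only real number in the set; the other two values are limits, see (the limit of > 1.66 h in this assay, at which 2 of the 3 values shown sit). Compound 4 `C=CC(=O)NCc1coc(-c2c(N)ncnc2Nc2ccc(Cl)c(Cl)c2F)n1` differs from compound 3 by 3,4-dichloro-2-fluorophenyl in place of 3-chloro-4-fluorophenyl on a nitrogen on an aromatic ring. Going by the values given here, two measured steps touch the same aryl group on that nitrogen: an at least 11-fold lower number from compound 1 to compound 3 (1.04 log units; beyond the scatter) and an at least 11-fold lower number from compound 2 to compound 3 (1.04 log units; beyond the scatter). Both are large and both run downward toward compound 3, but each removes a whole aryloxy group rather than changing the halogen pattern of the ring that stays. The step that the two limits leave unreadable from compound 1 to compound 2 is not readable. Among the compounds with values here, no measured step exchanges one halogen pattern for another on this ring, so the coming step has no direct anchor; a change of this kind is expected to stay within the scatter or at most just beyond it, in this assay. Compound 4 is therefore expected at 0.25 h, with a range from 0.1 h to 0.7 h. The expected step is a 1.7-fold higher number from compound 3 to compound 4 (0.22 log units; within the scatter).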

Compound 4, half-life: > 1.66 h
Compound 4: no number, only a limit (the forecaster's own chance of this, stated with the estimate: 5%); middle value at least 6.6-fold (0.82 log units) from the limit.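

In this assay, a change of halogen pattern alone on the aryl group on this nitrogen moves the read-out strongly, with an at least 11-fold higher number from compound 3 to compound 4 (1.04 log units; beyond the scatter). Compound 4 gives > 1.66 h, which is a limit and not a number. The earlier large steps each removed a whole aryloxy group, whereas compound 4 carries no aryloxy group and still reaches the limit shared with compounds 1 and 2, so such a group is not needed at this position to reach it: the limit of > 1.66 h in this assay, at which 3 of the 4 values shown sit.

With compounds 1, 2 and 4 all at that limit, their order in this assay cannot be read, and the step to compound 4 is known only as a minimum size. From the compounds shown here alone, it remains open which part of the change from 3-chloro-4-fluorophenyl to 3,4-dichloro-2-fluorophenyl carries the step, and whether a trifluoromethyl or methoxy group on this aryl ring would give the same result.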